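Series notes: aryl exchange on the sulfonamide nitrogen

A few compounds are considered here, and "the series" means these few. Any claim that something is new, unique, unknown or untested is made for them only; others in the source may bear on it.

Measured so far:
compound 1 `CC(C)CN(Cc1ccccc1C(F)(F)F)S(=O)(=O)c1ccc2c(c1)C(O)CC(C1CCOCC1)O2` — 4.23
compound 2 `CC(C)CN(c1ccc(F)cc1F)S(=O)(=O)c1ccc2c(c1)C(O)CC(C1CCOCC1)O2` — 3.53

In a physicochemical assay for lipophilicity, at pH 7.4 (on this read-out higher numbers stand for higher lipophilicity and lower numbers for lower lipophilicity), compound 2 gives 3.53, the lower of the two numbers; compound 1 gives 4.23. Within the data shown here, the only measured step, a number 0.70 log units lower from compound 1 to compound 2 (beyond the scatter), concerns a different exchange at the same nitrogen, so it bears only loosely on the next change. Compound 3 `Cc1ccc(N(CC(C)C)S(=O)(=O)c2ccc3c(c2)C(O)CC(C2CCOCC2)O3)c(C)c1` differs from compound 2 by 2,4-dimethylphenyl in place of 2,4-difluorophenyl on a sulfonamide nitrogen. Among the measured compounds shown here, no measured pair sets methyl against fluorine, so the expectation rests on the change itself: a modest rise is expected, a number 0.67 log units higher from compound 2 to compound 3 (beyond the scatter). Compound 3 is estimated at 4.2, within 3.8 to 4.6.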

Compound 3, distribution coefficient: 4.19
The estimate for compound 3 lay 0.01 log units above the measured number; low and high end bracket the measured number.
By their numbers in this assay, from the lowest: compound 2; then compounds 3 and 1 (each within the scatter of the next).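

In this assay the exchange at the sulfonamide nitrogen gives a number 0.66 log units higher from compound 2 to compound 3 (beyond the scatter) with the heavy-atom count unchanged, so swapping the two substituents on the aromatic ring alone moves the number beyond the scatter. The comparison with the benzyl compound gives a number 0.04 log units lower from compound 1 to compound 3 (within the scatter) and leaves 2,4-dimethylphenyl and 2-(trifluoromethyl)benzyl unseparated on this read-out. Nothing available accounts for either step. Still open, going by these compounds, is how an aryl group bearing an amine or a carboxylic acid would read at this nitrogen, and whether the same exchange gives a similar step on a benzyl group.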